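Carbamate chain in place of phenyl on the benzyl arm

This account rests on a few compounds, and the source may have more. Where it says the series, first, only, none or still open, it means among the compounds named here.

Compound 3 `CC1=C(N2CC2)C(=O)C(Cc2ccccc2)=C(N2CC2)C1=O` gives 4.26 in a functional assay on L1210 cells (Mus musculus), with a stated time of 1 days (a higher number here means a more potent compound, by a factor of ten per unit of this negative logarithm, a lower number a less potent compound), the lowest of the three numbers; compound 2 `COC(CO)C1=C(N2CC2)C(=O)C(C)=C(N2CC2)C1=O` gives 5.27 and compound 1 `CC1=C(N2CC2)C(=O)C(C(C)COC(N)=O)=C(N2CC2)C1=O` gives 5.31. The unmeasured compound 4 `CC1=C(N2CC2)C(=O)C(CCCOC(N)=O)=C(N2CC2)C1=O` differs from compound 3 by 2-(carbamoyloxy)ethyl in place of phenyl on a saturated chain carbon bound to a double-bonded ring carbon. Going by the values given here, two measured steps bear on this change: a number 1.05 log units lower from compound 1 to compound 3 (beyond the scatter) and a number 1.01 log units lower from compound 2 to compound 3 (beyond the scatter), both beyond the scatter, each putting an aromatic ring where a ring-free group had stood. Compound 4 reverses that kind of exchange, so a step up of about the same size is expected in this assay: a number 0.99 log units higher from compound 3 to compound 4 (beyond the scatter). Compound 4 is therefore estimated at 5.25, with a range from 4.75 to 5.75.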

Compound 4, logarithm of the reciprocal of the active concentration, log(1/C): 5.48
Compound 4: middle estimate off by 0.23 log units, on the low side, within the range that was stated.
By their numbers in this assay, from the lowest: compound 3; then compounds 2, 1 and 4 (each within the scatter of the next).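

In this assay the direct exchange of phenyl for 2-(carbamoyloxy)ethyl on this saturated chain carbon gives a number 1.22 log units higher from compound 3 to compound 4 (beyond the scatter) as its step, so a ring-free carbamate chain here lifts the benzyl compound clear of the scatter. The other two new steps, a number 0.21 log units higher from compound 2 to compound 4 (within the scatter) and a number 0.17 log units higher from compound 1 to compound 4 (within the scatter), leave compound 4 not distinguishable from the two earlier ring-free compounds. No evidence bears on the cause of these steps. From the compounds shown here alone, whether an amine, a carboxylic acid or a longer chain in place of the carbamate holds this level stays open.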